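Replacing the Amine-Bearing Chain: an Expected Loss of Potency

A few compounds are considered here, and "the series" means these few. Any claim that something is new, unique, unknown or untested is made for them only; others in the source may bear on it.

Compound 1 `CCCCNc1nc(N)nc(C)c1CCCCO` gives 1310 nM in an assay on HEK293 cells for agonist activity at Toll-like receptor 8 (Homo sapiens), read by spectrophotometry; a higher number here means that more compound is needed for the effect, a lower number that less compound is needed. Compound 2 `CCCCNc1nc(N)nc(C)c1C#CCN1CCCCC1` gives 3790 nM. Compound 3 `CCCCNc1nc(N)nc(C)c1CCCN(C)C` gives 126 nM.

Compound 3 therefore stands lowest of the three numbers, with compound 1 nearest and compound 2 furthest from it. Compound 4 `CCCC#Cc1c(C)nc(N)nc1NCCCC` differs from compound 3 in one place: pent-1-yn-1-yl in place of 3-(dimethylamino)propyl on an aromatic carbon. Within the data shown here, the one measured step that bears on this change is a 10-fold lower number from compound 1 to compound 3 (1.02 log units; beyond the scatter), where the dimethylamino group entered the chain; compound 4 takes that group away entirely, and compound 2, whose nitrogen sits in a different chain, shows the highest number of all. A sizeable step upward is therefore expected, a 20-fold higher number from compound 3 to compound 4 (1.30 log units; beyond the scatter). Compound 4 is estimated at 2500 nM, with a range from 600 nM to 10000 nM.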

Compound 4, half-maximal effective concentration: 5000 nM
Compound 4: the middle estimate sits 2.0-fold (0.30 log units) below what was measured; the range from low to high includes it.
By their numbers in this assay, from the lowest: compound 3; then compound 1; then compounds 2 and 4 (each within the scatter of the next).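

Among these compounds, at this aromatic carbon, this assay shows a 40-fold higher number from compound 3 to compound 4 (1.60 log units; beyond the scatter) when pent-1-yn-1-yl replaces 3-(dimethylamino)propyl, the largest step so far. Ethyl in place of piperidin-1-yl gives a 1.3-fold higher number from compound 2 to compound 4 (0.12 log units; within the scatter) so those two compounds cannot be told apart, while pent-1-yn-1-yl in place of 4-hydroxybutyl gives a 3.8-fold higher number from compound 1 to compound 4 (0.58 log units; beyond the scatter) as a more modest rise. No measurement shown here explains these steps. Still open, on these data alone, is whether a saturated pentyl chain would match pent-1-yn-1-yl, and whether a primary amine at the end of the propyl chain would match dimethylamino.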